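The source may hold more compounds than are shown below. What is called first, only, known or untested is meant among the compounds shown, and "the series" means these compounds.

Compound 2, `Cn1c(-c2cc(-c3c(F)cccc3Cl)no2)cnc1C1CCNCC1`, stands higher of the two numbers in hand: in an assay on a protein complex for positive allosteric modulation of Neuronal acetylcholine receptor; alpha4/beta2 (Homo sapiens) (a higher number here means a larger maximal response, a lower number a smaller maximal response), compound 2 gives 71%. Compound 1, `Clc1ccccc1-c1cc(-c2cnn(C3CCNCC3)c2)on1`, gives 38% in this assay, a gap beyond the usual scatter, so compound 2 is the stronger of the pair. Compound 3, `CCn1c(-c2cc(-c3c(F)cccc3Cl)no2)cnc1C1CCNCC1`, differs from compound 2 by methyl in place of hydrogen on a saturated chain carbon bound to an aromatic nitrogen. Among the compounds with values here, no measured pair shows a change of this kind, so there is nothing to size the step on. The step from compound 2 to compound 3 is expected to be small, a number 3 percentage points lower from compound 2 to compound 3 (within the scatter), likely not beyond the scatter. Compound 3 is therefore estimated at 68%, in a range from 50% to 85%, because compound 2 gives 71%.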

Compound 3, largest response reached (reported as efficacy), in percent of the reference or control that the assay uses: 87%
For compound 3 the middle estimate is 19 percentage points below the measured one, and the stated range ends below it.
By their numbers in this assay, from the lowest: compound 1; then compound 2; then compound 3.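

In this assay the change from methyl to ethyl, on a saturated chain carbon bound to an aromatic nitrogen, gives a number 16 percentage points higher from compound 2 to compound 3 (beyond the scatter) and is the only step shown at this position. The position therefore responds to a single added methyl, and the longer chain raises the maximal response rather than lowering it. Nothing available accounts for this rise. Open, on these data alone, is whether a propyl chain would raise the response further or whether the rise ends at ethyl. Also open, as far as these compounds go, is how a cyclopropyl ring or a hydroxyethyl group would fare at this position.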